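Amine side chains: from compound 2 to compound 3

The compounds below may be only part of what the source reports. "The series", "measured", "known", "first", "only" and "open" are said of these compounds alone.

Values in a functional assay on MCF7 cells (Homo sapiens) for inhibition, read by MTT assay, with a stated time of 72 h; a lower number here means a stronger inhibitor, a higher number a weaker inhibitor:
compound 1 `C/C1=C\CC[C@@]2(C)O[C@@H]2[C@H]2OC(=O)[C@@H](CN3CCCCC3)[C@@H]2C[C@H]1O`: 16000 nM
compound 2 `C/C1=C\CC[C@@]2(C)O[C@@H]2[C@H]2OC(=O)[C@@H](CN3CCN(C)CC3)[C@@H]2C[C@H]1O`: 33000 nM

Compound 2, at 33000 nM, holds the higher of the two numbers and is the weaker inhibitor of the pair. Next is compound 3 `C/C1=C\CC[C@@]2(C)O[C@@H]2[C@H]2OC(=O)[C@@H](CN(C)CCN(C)C)[C@@H]2C[C@H]1O`, with this change: (2-(dimethylamino)ethyl)(methyl)amino in place of 4-methylpiperazin-1-yl on a saturated chain carbon bound to a saturated ring carbon. In words, (2-(dimethylamino)ethyl)(methyl)amino stands in place of 4-methylpiperazin-1-yl on a saturated chain carbon bound to a saturated ring carbon. For the measured compounds named here, the only measured step that bears on this is a 2.1-fold higher number from compound 1 to compound 2 (0.31 log units; beyond the scatter), which is modest. Going by the values given here, it swaps a different pair of groups at the same place, and no measured compound carries an open chain there. No step beyond the scatter is therefore expected, and no firm direction. The expected step is a 1.3-fold lower number from compound 2 to compound 3 (0.10 log units; within the scatter). Compound 3 is estimated at 26000 nM, with an expected range of 11000 nM to 60000 nM.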

Compound 3, half-maximal inhibitory concentration: 14000 nM
Compound 3: the middle estimate sits 1.9-fold (0.27 log units) above what was measured, within the range that was stated.
By their numbers in this assay, from the lowest: compounds 3 and 1 (each within the scatter of the next); then compound 2.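

In this assay, the open chain is tolerated on a saturated chain carbon bound to a saturated ring carbon: a 2.4-fold lower number from compound 2 to compound 3 (0.37 log units; beyond the scatter), a modest gain for a group with the same heavy-atom, carbon and nitrogen counts as 4-methylpiperazin-1-yl but no ring. Against piperidin-1-yl there is no separation, with a 1.1-fold lower number from compound 1 to compound 3 (0.06 log units; within the scatter), so among these three amines a ring is not needed and compound 2 alone stands apart as the weakest. No available evidence accounts for these differences.

From the compounds shown here alone, it remains open whether a longer chain carrying the dimethylamino group, or a primary amine at this place, would move the value beyond that of compound 3. A morpholine ring or a carboxylic acid at the same place also remains untested in the compounds shown here.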